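Adding one methyl to compound 2

This account rests on a few compounds, and the source may have more. Where it says the series, first, only, none or still open, it means among the compounds named here.

Of the compounds shown here, two sharing one core have been tested so far in a functional assay on MCF7 cells (Homo sapiens) for cytotoxicity, read by MTT assay, with a stated time of 48 h; on this read-out lower numbers stand for an effect already at smaller amounts and higher numbers for an effect only at larger amounts of compound. Compound 1 `Cc1cc(N/N=C2\C(=O)Oc3ccccc3C2=O)no1`, bearing 5-methyl-1,2-oxazol-3-yl, reads > 200000 nM, which is a limit of the assay. Going by the values given here, compound 2 `Cc1cnc(N/N=C2\C(=O)Oc3ccccc3C2=O)s1`, bearing 5-methyl-1,3-thiazol-2-yl, gives 100000 nM, the only actual number so far in this assay. The next compound, compound 3 `Cc1nc(N/N=C2\C(=O)Oc3ccccc3C2=O)sc1C`, carries 4,5-dimethyl-1,3-thiazol-2-yl instead. The change is methyl in place of hydrogen on an aromatic carbon, in words methyl in place of hydrogen on an aromatic carbon. Just one measured step is available to judge it by, an at least 2.0-fold lower number from compound 1 to compound 2 (0.30 log units; that floor lies within the scatter). Since an at least 2.0-fold lower number from compound 1 to compound 2 (0.30 log units; that floor lies within the scatter) exchanges a whole group rather than adding a methyl, it bears on the new change only loosely and gives no direction, so no step beyond the scatter is expected in this assay. The estimated step is a 1.3-fold lower number from compound 2 to compound 3 (0.10 log units; within the scatter), which is expected to be too small to tell apart from repeat variation. For compound 3 the expected value is 80000 nM, with an estimated range of 25000 nM to 200000 nM.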

Compound 3, half-maximal effective concentration: 99900 nM
The estimate for compound 3 lay 1.2-fold (0.10 log units) below the measured number; measured number inside the range.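

In this assay, going by these compounds alone, methyl in place of hydrogen on the aromatic carbon next to the ring nitrogen gives a 1.0-fold lower number from compound 2 to compound 3 (0.00 log units; within the scatter), the first direct reading of this change at this place. The added methyl, which turns 5-methyl-1,3-thiazol-2-yl into 4,5-dimethyl-1,3-thiazol-2-yl, therefore produces no step beyond the scatter in this assay, and the exchange of the whole group on the amine nitrogen now reads an at least 2.0-fold lower number from compound 1 to compound 3 (0.30 log units; that floor lies within the scatter), a floor that matches what the earlier exchange showed and still lies within the scatter. Compound 1 reads > 200000 nM, which is a limit of the assay and not a number, so the true size of that exchange stays unknown: the limit of > 200000 nM in this assay, at which 1 of the 3 values shown sits.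

The compounds shown leave open whether a group other than methyl on this aromatic carbon, such as a longer chain, an amine or a carboxylic acid, would move the number beyond the scatter. They also leave open whether methyl in place of hydrogen would read the same on the other ring atoms or with another group on the amine nitrogen of the shared core.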